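This account rests on a few compounds, and the source may have more. Where it says the series, first, only, none or still open, it means among the compounds named here.

Measured in an ADME assay on HepG2 2.2.15 cells (Homo sapiens) for cytotoxicity; on this read-out lower numbers stand for higher toxicity in this test and higher numbers for lower toxicity in this test:
compound 1 `CC(C)(C)OC(=O)Nc1ncc(C(Oc2ccc(F)c(Cl)c2)c2ccc(Cl)cc2)s1`: > 50000 nM, a limit of the assay, not a number.
compound 2 `O=C(Nc1ncc(C(OCc2ccc(F)cc2Br)c2ccccc2)s1)c1cccs1`: "not toxic" (no number reported), no number reported.
compound 3 `Clc1ccc(C(Oc2ccc3cc(Br)ccc3c2)c2cnc(NCC3CCCCC3)s2)cc1`: "not toxic" (no number reported), no number reported.

Compound 3 thus has no single number in this assay; of the other two entries, one is a limit and one also lacks a number, so no order among the three can be read. The only numeric anchor is the limit of > 50000 nM in this assay, at which 1 of the 3 values shown sits. Compound 4 `CCCCCC(=O)Nc1ncc(C(Oc2ccc3cc(Br)ccc3c2)c2ccc(Cl)cc2)s1` differs from compound 3 by pentylcarbonyl in place of cyclohexylmethyl on a nitrogen on an aromatic ring; pentylcarbonyl in place of cyclohexylmethyl on a nitrogen on an aromatic ring. Going by the values given here, no measured step exists for this change, and nothing among the three entries points in either direction, so no shift beyond the scatter is expected, with a fair chance that only a limit is again reported. Compound 4 is expected at 50000 nM, with an estimated range of 20000 nM to 100000 nM.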

Compound 4, half-maximal cytotoxic concentration: > 50000 nM
Compound 4 ended at the assay's limit (the forecaster's own chance of this, stated with the estimate: 70%); the middle value lies on the limit itself.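

In this assay compound 4 gives > 50000 nM, which is a limit. Compound 3 has no number, so no step can be read between compound 3 and compound 4. The compounds shown leave open any actual cytotoxic concentration, the sole numeric anchor being this: the limit of > 50000 nM in this assay, at which 2 of the 4 values shown sit.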